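The source may report more compounds than this note shows. Statements on the series, on what has been measured and on what is new or still open speak of the compounds shown alone.

In a functional assay on MCF7 cells (Homo sapiens) for cytotoxicity (a higher number here means a weaker inhibitor, a lower number a stronger inhibitor), compound 1 (`CCC(CO)Nc1nc(NCc2ccccc2)c2nc(N)n(C(C)C)c2n1`) gives 60000 nM. Compound 2 (`CCCOc1nc2c(NCc3ccccc3)nc(NC(CC)CO)nc2n1C(C)C`) gives 50000 nM, so the two values lie within the scatter of each other and compound 1 holds no distinct place beside compound 2. Compound 3 (`CCC(CO)Nc1nc(NCc2ccccc2)c2nc(NCCCO)n(C(C)C)c2n1`) has not yet been measured. It differs from compound 1 by a single change, 3-hydroxypropyl in place of hydrogen on a nitrogen on an aromatic ring, or amino to (3-hydroxypropyl)amino: 3-hydroxypropyl in place of hydrogen on a nitrogen on an aromatic ring. Among the measured compounds shown here, only one measured step bears on this, as it also alters that amino group, with propoxy in place of amino: a 1.2-fold lower number from compound 1 to compound 2 (0.08 log units; within the scatter). This lone step stayed within the scatter, so no step beyond the scatter is expected in this assay, though one step is thin evidence. The expected change is a 1.3-fold lower number from compound 1 to compound 3 (0.12 log units; within the scatter). For compound 3 the estimated value is 45000 nM, with a range from 15000 nM to 100000 nM.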

Compound 3, half-maximal inhibitory concentration: 40000 nM
Beside the measured number, compound 3's estimate is 1.1-fold (0.05 log units) above it, within the range that was stated.
By their numbers in this assay, from the lowest: compounds 3, 2 and 1 (each within the scatter of the next).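

In this assay, putting 3-hydroxypropyl on the amino nitrogen of compound 1 gives a 1.5-fold lower number from compound 1 to compound 3 (0.18 log units; within the scatter), so this place accepts a group of 4 heavy atoms, with a hydrogen-bond donor and acceptor, without a step beyond the scatter. Exchanging the link and the end of the chain gives a 1.3-fold lower number from compound 2 to compound 3 (0.10 log units; within the scatter), so (3-hydroxypropyl)amino and propoxy on this aromatic carbon also cannot be told apart in this assay. No measurement on hand accounts for these values lying so close together.

The compounds shown leave open whether a carboxylic acid or a tertiary amine at this place, or a much longer chain, would produce a step beyond the scatter. They also leave open whether any change elsewhere on the shared core would do so.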